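Replacing a benzyl substituent: what compound 4 might tolerate

The compounds below may be only part of what the source reports. "The series", "measured", "known", "first", "only" and "open" are said of these compounds alone.

Compound 1 `Cn1cc(SCc2nnc(SCc3ccccc3)n2-c2c(Cl)cccc2Cl)c2ccccc21`: in a toxicity assay on HEK-293T cells (Homo sapiens) for cytotoxicity, read by CCK-8 assay, with a stated time of 48 h (a lower number here means that less compound is tolerated, a higher number that more compound is tolerated), compound 1 gives > 100000 nM, which is a limit of the assay.
Compound 2 `Cn1cc(SCc2nnc(SCc3ccccc3OC(F)(F)F)n2-c2c(Cl)cccc2Cl)c2ccccc21`: compound 2 gives > 100000 nM, also a limit of the assay.
Compound 3 `Cn1cc(SCc2nnc(SCc3cc(C(F)(F)F)ccc3Cl)n2-c2c(Cl)cccc2Cl)c2ccccc21`: compound 3 gives 53800 nM.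

Compound 2 therefore stands only at a limit, and it shares that position with compound 1 (the limit of > 100000 nM in this assay, at which 2 of the 3 values shown sit). Within the data shown here, compound 3 is the one member of the set with a number, and the steps to it read an at least 1.8-fold lower number from compound 1 to compound 3 (0.26 log units; that floor lies within the scatter) and an at least 1.8-fold lower number from compound 2 to compound 3 (0.26 log units; that floor lies within the scatter); both floors lie within the scatter, so no real change is established by them.

The step followed here replaces one benzyl group by another: 2,5-dichlorophenyl in place of 2-(trifluoromethoxy)phenyl on a saturated chain carbon bound to a sulfur. Compound 4 `Cn1cc(SCc2nnc(SCc3cc(Cl)ccc3Cl)n2-c2c(Cl)cccc2Cl)c2ccccc21` has not been measured. The step from compound 2 to compound 3 is the closest guide, since it leaves the same 2-(trifluoromethoxy)phenyl and brings in another chlorinated aryl; it points, if anywhere, only weakly downward. The step from compound 1 to compound 3 says the same. Compound 4 is thus expected to sit near the limit or a little below it, with the estimated step of an at least 1.3-fold lower number from compound 2 to compound 4 (0.12 log units; that floor lies within the scatter). The estimate for compound 4 is 75000 nM, between 30000 nM and 150000 nM.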

Compound 4, half-maximal cytotoxic concentration: > 100000 nM
Compound 4 gave a limit, no number; the forecaster's own chance of this, stated with the estimate: 45%; at least 1.3-fold (0.12 log units) between middle value and limit.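

In this assay compound 4 gives > 100000 nM, which is a limit of the assay and not a number. On the saturated chain carbon bound to a sulfur, 2,5-dichlorobenzyl in compound 4 therefore stands with the unsubstituted benzyl of compound 1 and the 2-(trifluoromethoxy)benzyl of compound 2, and the steps from these two compounds to compound 4 cannot be read: the limit of > 100000 nM in this assay, at which 3 of the 4 values shown sit. Among these compounds, the one readable new step, chloro in place of trifluoromethyl on an aromatic carbon, is the first readable step here that changes a single aromatic substituent, and it gives an at least 1.8-fold higher number from compound 3 to compound 4 (0.26 log units; that floor lies within the scatter), so it establishes no real change.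

Going by these compounds, how far compound 1, compound 2 and compound 4 lie beyond the limit stays open, and with it any order among them. The compounds shown also leave open how an amine, a carboxylic acid or a longer chain in place of the benzyl group at this position would read in this assay.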